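The compounds below may be only part of what the source reports. "The series", "measured", "known", "first", "only" and "open" are said of these compounds alone.

Compounds measured so far in a functional assay on MKN-74 cells (Homo sapiens) for antiproliferative activity, with a stated time of 24 h; on this read-out higher numbers stand for weaker inhibition and lower numbers for stronger inhibition:

- compound 1, `NC(=O)c1c(NC(=O)c2ccccc2Cl)sc2c1CCN(Cc1ccccc1)C2`: 14500 nM
- compound 2, `COc1ccccc1NC(=S)N1CCc2c(sc(NC(=O)c3ccccc3Cl)c2C(N)=O)C1`: 35200 nM
- compound 3, `CSc1ccccc1NC(=S)N1CCc2c(sc(NC(=O)c3ccccc3Cl)c2C(N)=O)C1`: 13800 nM

Compound 1 stands second highest of the three numbers in this assay; compound 3 is nearest, with a 1.1-fold lower number from compound 1 to compound 3 (0.02 log units; within the scatter), and compound 2 furthest, with a 2.4-fold higher number from compound 1 to compound 2 (0.39 log units; beyond the scatter). Between the two thioureas themselves there is a 2.6-fold lower number from compound 2 to compound 3 (0.41 log units; beyond the scatter).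

Compound 4, `NC(=O)c1c(NC(=O)c2ccccc2Cl)sc2c1CCN(C(=S)Nc1c(Cl)cccc1Cl)C2`, has not been measured. It differs from compound 1 as follows: a group of 11 heavy atoms (7 carbon, 1 nitrogen, 1 sulfur, 2 chlorine; one six-membered aromatic ring of carbon only) in place of a group of 7 heavy atoms (7 carbon; one six-membered aromatic ring of carbon only), on an amine nitrogen in a ring.

The two steps that bear on this are those from compound 1 to the other thioureas on the same amine nitrogen in a ring: a 2.4-fold higher number from compound 1 to compound 2 (0.39 log units; beyond the scatter) and a 1.1-fold lower number from compound 1 to compound 3 (0.02 log units; within the scatter). One lies beyond the scatter and one within it, and they point in opposite directions, so no step beyond the scatter is expected in this assay from compound 1 to compound 4; the estimated step is a 1.1-fold higher number from compound 1 to compound 4 (0.04 log units; within the scatter). Compound 4 is therefore expected to give about 16000 nM, with a range from 6000 nM to 40000 nM.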

Compound 4, half-maximal inhibitory concentration: 4020 nM
Compound 4: middle estimate off by 4.0-fold (0.60 log units), on the high side; measured number outside the range, below it.
By their numbers in this assay, from the lowest: compound 4; then compounds 3 and 1 (each within the scatter of the next); then compound 2.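

In this assay a thiourea on the amine nitrogen in a ring can do better than benzyl (a 3.6-fold lower number from compound 1 to compound 4 (0.56 log units; beyond the scatter)), whereas compound 3 stayed within the scatter of compound 1 and compound 2 gave a higher number. With the thiourea held constant, the aryl group on the amide-type nitrogen alone moves the number: 2,6-dichlorophenyl gives a clear drop both in place of 2-(methylsulfanyl)phenyl (a 3.4-fold lower number from compound 3 to compound 4 (0.54 log units; beyond the scatter)) and in place of 2-methoxyphenyl (an 8.8-fold lower number from compound 2 to compound 4 (0.94 log units; beyond the scatter)). No measurement in hand bears on why this aryl change lowers the number.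

Going by these compounds, whether the lower number needs both chlorines remains open, as a plain phenyl or a cyclohexyl on the same nitrogen would be needed to test it. Also open, on these data alone, is how a urea, with oxygen in place of the thiourea sulfur, would compare with compound 4.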